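Swapping a methoxyphenyl for a benzyl on the amine

The compounds below may be only part of what the source reports. "The series", "measured", "known", "first", "only" and "open" are said of these compounds alone.

Of the compounds shown here, three sharing one core have been tested in a functional assay on MGC-803 cells (Homo sapiens) for inhibition, read by sulforhodamine B assay; on this read-out higher numbers stand for weaker inhibition and lower numbers for stronger inhibition. Compound 1 `O=C1C(NC2CC2)=CC(=O)c2c1nc1n2[C@H]2OC[C@@H](O)[C@H]2OC1` carries a cyclopropyl on the amine nitrogen; in this assay compound 1 reaches only a limit, > 4000 nM, not a number. Compound 2 `COc1ccccc1NC1=CC(=O)c2c(nc3n2[C@H]2OC[C@@H](O)[C@H]2OC3)C1=O` carries a 2-methoxyphenyl there instead and in this assay compound 2 gives 1670 nM. Compound 3 `CCOc1ccccc1NC1=CC(=O)c2nc3n(c2C1=O)[C@H]1OC[C@@H](O)[C@H]1OC3` is the ethoxy counterpart of compound 2, and in this assay compound 3 gives 2450 nM, a gap from compound 2 within the usual scatter. Going by the values given here, the one computed step, an at least 2.3-fold lower number from compound 1 to compound 2 (0.37 log units; beyond the scatter), shows that a 2-methoxyphenyl beats a cyclopropyl on this nitrogen, though the size of that step is bounded by the limit of > 4000 nM in this assay, at which 1 of the 3 values shown sits.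

Compound 4 `O=C1C(NCc2ccccc2)=CC(=O)c2c1nc1n2[C@H]2OC[C@@H](O)[C@H]2OC1` is the next member: benzyl in place of 2-methoxyphenyl on an amine nitrogen. Among the compounds with values here, no measured step compares an aromatic ring bound directly to the nitrogen with one set off by a single carbon, so the expectation rests only on the fact that an aromatic group stays present. For compound 4 a step of a 1.3-fold higher number from compound 2 to compound 4 (0.12 log units; within the scatter) is expected, within the scatter. Compound 4 is therefore estimated at 2200 nM, with a range from 1000 nM to 5000 nM.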

Compound 4, half-maximal inhibitory concentration: 3490 nM
Estimate against measurement, compound 4: 1.6-fold (0.20 log units) below; low and high end bracket the measured number.
By their numbers in this assay, from the lowest: compounds 2, 3 and 4 (each within the scatter of the next, the first and the last beyond it). At a limit, above all of these: compound 1.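

In this assay, the step of a 2.1-fold higher number from compound 2 to compound 4 (0.32 log units; beyond the scatter) shows that keeping a six-membered aromatic ring on this amine nitrogen does not by itself keep the number of compound 2. This single change does two things at once: it removes the methoxy group and sets the ring one carbon away from the nitrogen, so the step cannot be assigned to either alone. The other step, an at least 1.1-fold lower number from compound 1 to compound 4 (0.05 log units; that floor lies within the scatter), does not place benzyl ahead of cyclopropyl, and it is only a floor set by a limit: the limit of > 4000 nM in this assay, at which 1 of the 4 values shown sits.

The compounds shown leave open whether the methoxy group or the direct link between ring and nitrogen matters more. A plain phenyl on the same nitrogen would separate the two, and a 2-phenylethyl would show what a longer chain does.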